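This account rests on a few compounds, and the source may have more. Where it says the series, first, only, none or still open, it means among the compounds named here.

Compound 1, `CC(C)(C)OC(=O)Nc1ncc(C(Oc2ccc(OCc3ccccc3)cc2)c2ccc(Cl)cc2)s1`, and compound 2, `O=C(Nc1ncc(C(Oc2ccc3cc(Br)ccc3c2)c2ccc(Cl)cc2)s1)C1CCCO1`, share a core and were both examined in an ADME assay on HepG2 2.2.15 cells (Homo sapiens) for cytotoxicity; a lower number here means that less compound is tolerated, a higher number that more compound is tolerated. For compound 1 the result is a limit of the assay rather than a number: in this assay compound 1 gives > 50000 nM, which is the limit of > 50000 nM in this assay, at which 1 of the 2 values shown sits. Within the data shown here, compound 2 stands without a single number in this assay; the only report for compound 2 is "not toxic" (no number reported), so the two values together show nothing but a lack of measurable cytotoxicity across this pair.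

Compound 3, `O=S(=O)(Nc1ncc(C(Oc2ccc3cc(Br)ccc3c2)c2ccc(Cl)cc2)s1)c1cccc2nsnc12`, has not yet been measured in this assay. It differs from compound 2 at one place: a group of 12 heavy atoms (6 carbon, 2 nitrogen, 2 oxygen, 2 sulfur; one five-membered aromatic ring with 3 hetero atoms, one six-membered aromatic ring of carbon only) in place of a group of 7 heavy atoms (5 carbon, 2 oxygen; one five-membered non-aromatic ring with 1 hetero atom), on a nitrogen on an aromatic ring. Among the measured compounds shown here, no step between measured compounds is available to anchor this change, so the size of any step from compound 2 to compound 3 in this assay cannot be drawn from the data; the expectation is for no change beyond the scatter, with the result again most likely a limit. For compound 3 in this assay the estimate is 50000 nM, within a range from 15000 nM to 100000 nM.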

Compound 3, half-maximal cytotoxic concentration: "not toxic" (no number reported)
Compound 3: no number reported; the estimate stays without a comparison.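

Among these compounds, compound 3, like compound 2, is reported in this assay only as "not toxic", so no step from compound 2 to compound 3 can be read. Compound 1 alone has a printed value, and it is a limit: the limit of > 50000 nM in this assay, at which 1 of the 3 values shown sits.

The compounds shown leave open at what concentration, if any, each would become cytotoxic.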